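Pyridin-4-yl in place of methyl on the shared core

A few compounds are considered here, and "the series" means these few. Any claim that something is new, unique, unknown or untested is made for them only; others in the source may bear on it.

Measured in a functional assay on Jurkat cells for inhibition of nuclear factor NF-kappa-B complex (Homo sapiens); a lower number here means a stronger inhibitor, a higher number a weaker inhibitor:
Compound 1, `CCOC(=O)c1cnc(C(F)(F)F)nc1NN1C(=O)C=C(C)C1=O`, gives 1000 nM.
Compound 2, `CCOC(=O)c1cnc(C)nc1NN1C(=O)C=C(C)C1=O`, gives 16000 nM.
Compound 3, `CCOC(=O)c1cnc(-c2cccs2)nc1NN1C(=O)C=C(C)C1=O`, gives 20 nM.

The three compounds share one core and differ only in the group on one aromatic carbon. Compound 2, with a methyl there, stands at the highest number of the three: compound 1 is the nearest, a 16-fold higher number from compound 1 to compound 2 (1.20 log units; beyond the scatter) read the other way, and compound 3 the furthest, by an 800-fold lower number from compound 2 to compound 3 (2.90 log units; beyond the scatter). Compound 4, `CCOC(=O)c1cnc(-c2ccncc2)nc1NN1C(=O)C=C(C)C1=O`, has not yet been measured. Its change from compound 2 is pyridin-4-yl in place of methyl on an aromatic carbon, the new group sitting between two ring nitrogen atoms, meta to a group of 9 heavy atoms and para to an ethoxycarbonyl group. Among the measured compounds shown here, two measured steps bear on it. an 800-fold lower number from compound 2 to compound 3 (2.90 log units; beyond the scatter) puts thiophen-2-yl on the same carbon, and a 50-fold lower number from compound 1 to compound 3 (1.70 log units; beyond the scatter) puts thiophen-2-yl in place of trifluoromethyl; both are large steps downward. For the measured compounds named here, no measured step tells how a six-membered aromatic ring with 1 hetero atom compares with thiophen-2-yl at this carbon, so the range must be wide. The step from compound 2 to compound 4 is expected to be a 320-fold lower number from compound 2 to compound 4 (2.51 log units; beyond the scatter). Compound 4 is therefore estimated at 50 nM in this assay, between 10 nM and 300 nM.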

Compound 4, half-maximal inhibitory concentration: 6000 nM
For compound 4 the middle estimate is 120-fold (2.08 log units) below the measured one, and the stated range ends below it.
By their numbers in this assay, from the lowest: compound 3; then compound 1; then compound 4; then compound 2.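

In this assay, an aromatic ring on this carbon does not by itself bring the large drop seen with compound 3: there is only a 2.7-fold lower number from compound 2 to compound 4 (0.43 log units; beyond the scatter), while a 300-fold higher number from compound 3 to compound 4 (2.48 log units; beyond the scatter) separates the two ring-bearing compounds widely. Pyridin-4-yl also falls short of the much smaller trifluoromethyl, with a 6.0-fold higher number from compound 1 to compound 4 (0.78 log units; beyond the scatter), so compound 4 goes against any reading that a ring here gives a lower number than a non-ring group, and that reading now rests on compound 3 alone. Nothing at hand accounts for the gap between the thiophen-2-yl and pyridin-4-yl compounds.

The compounds shown leave open whether that gap goes with the size of the ring or with the ring nitrogen of pyridin-4-yl, a question on which phenyl or furan-2-yl on this carbon would bear. Also open, from the compounds shown here alone, is whether the low number of compound 3, 20 nM, would survive a change elsewhere on the shared core, such as a carboxylic acid in place of the ethoxycarbonyl group.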